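The compounds below may be only part of what the source reports. "The series", "measured", "known", "first", "only" and "open" are said of these compounds alone.

Measured so far:
- compound 1 `CN(C)c1cccc(Oc2ccc3c(NCCCNCc4ccco4)ccnc3c2)c1`: 14500 nM
- compound 2 `COc1cccc(CNCCCNc2ccnc3cc(Oc4cccc(N(C)C)c4)ccc23)c1O`: 14500 nM

In a physicochemical assay for solubility, with a stated time of 18 h, at pH 7.4 (a higher number here means a more soluble compound, a lower number a less soluble compound), compound 2 gives 14500 nM, and compound 1 gives 14500 nM. The two values are level at the digits shown: the one measured step, no change at the digits printed from compound 1 to compound 2 (within the scatter), lies within the usual scatter, and it concerned the group on the saturated chain carbon, not the part of the molecule that changes next.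

Compound 3 `COc1cccc(CNCCCNc2ccnc3cc(-c4cccc5ccccc45)ccc23)c1O` differs from compound 2 at an aromatic carbon of the shared core: naphthalen-1-yl in place of 3-(dimethylamino)phenoxy on an aromatic carbon. For the measured compounds named here, no measured step covers a change at this position, so nothing seen so far predicts its size directly. The leaving group carries two hydrogen-bond acceptors while the entering naphthalen-1-yl carries none, and on that basis a step downward in this assay is expected, of a size that should go beyond the scatter.

For compound 3 the expected value in this assay is 4000 nM, with a range from 1000 nM to 14000 nM, which means an estimated step of a 3.6-fold lower number from compound 2 to compound 3 (0.56 log units; beyond the scatter).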

Compound 3, solubility: 32000 nM
Compound 3: middle estimate off by 8.0-fold (0.90 log units), on the low side; measured number above the stated range.
By their numbers in this assay, from the lowest: compounds 1 and 2 (each within the scatter of the next); then compound 3.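

At this aromatic carbon of the shared core, swapping 3-(dimethylamino)phenoxy for naphthalen-1-yl gives a 2.2-fold higher number from compound 2 to compound 3 (0.34 log units; beyond the scatter) in this assay, so this is the first change among the compounds shown that moves the number by more than the scatter, though only modestly. The leaving group carries hydrogen-bond acceptors and the entering group carries none, yet the number went up, so in this one pair, losing those acceptors did not go with a lower reading. Nothing available explains why the number rose at this position.

The swap alters several things at once: the oxygen link goes, the dimethylamino group goes, and a second six-membered aromatic ring comes in, so a single pair cannot show which of these matters. A plain phenoxy or phenyl group on the same carbon would begin to separate these parts, and a naphthalen-1-yl compound carrying furan-2-yl on the chain in place of 2-hydroxy-3-methoxyphenyl would test whether the step holds with the other end of the molecule changed.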